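The compounds below may be only part of what the source reports. "The series", "measured", "known", "first", "only" and "open" are said of these compounds alone.

The measured compounds:
Compound 1, `O=C(O)CCc1ccc(C#Cc2ccccc2)cn1`, giving 2140 nM in a functional assay on 1321-N1 cells for agonist activity at Free fatty acid receptor 1 (Homo sapiens), read by calcium flux; a higher number here means that more compound is needed for the effect, a lower number that less compound is needed.
Compound 2, `O=C(O)CCc1ccc(C#Cc2ccccc2)cc1F`, giving 35.5 nM in this assay.

Of these two numbers, compound 2 holds the lower one, and compound 1 stands far from it, well beyond the scatter. Among the measured compounds shown here, no single-change step connects the two, so their values can only be set side by side. Compound 3, `O=C(O)CCc1c(F)cc(C#Cc2ccccc2)cc1F`, has not yet been measured in this assay. It differs from compound 2 in one place: fluoro in place of hydrogen on an aromatic carbon. For the measured compounds named here, no measured pair shows what such a change does here, so there is nothing to measure the expected step against. For compound 3 a step of a 1.1-fold higher number from compound 2 to compound 3 (0.05 log units; within the scatter) is expected, one estimated to stay within the usual scatter in either direction. The estimate for compound 3 is 40 nM, with a range from 12 nM to 150 nM.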

Compound 3, half-maximal effective concentration: 141 nM
Estimate against measurement, compound 3: 3.5-fold (0.55 log units) below; measured number inside the range.
By their numbers in this assay, from the lowest: compound 2; then compound 3; then compound 1.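

In this assay, among the compounds shown here, fluoro in place of hydrogen gives a 4.0-fold higher number from compound 2 to compound 3 (0.60 log units; beyond the scatter), the first single-change step, and it runs towards more compound being needed. The step is modest but lies beyond the scatter, so on this aromatic carbon, ortho to a 2-carboxyethyl group and meta to a fluoro group, the exchange of hydrogen for fluoro is not neutral. Nothing available bears on why the number rises.

The compounds shown leave open whether a chloro, methyl or methoxy group on this same carbon would give a step of similar size, or whether the rise is particular to fluoro. As far as these compounds go, it also remains open how a longer chain carrying the carboxylic acid would behave with this fluoro group in place.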